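Swapping the benzylsulfanyl arm: from compound 1 to compound 4

The source may report more compounds than this note shows. Statements on the series, on what has been measured and on what is new or still open speak of the compounds shown alone.

Measured so far:
compound 1, `CN(C)c1ccc(/C=C(/SCc2ccc(Cl)cc2Cl)C(=O)c2ccc(Cl)cc2)cc1`, 50000 nM
compound 2, `O=C(/C(=C\c1ccc(O)cc1)SCc1ccc(F)cc1)c1ccc(Br)cc1`, 10000 nM
compound 3, `COc1ccc(/C=C(/SCc2ccc(Cl)cc2)C(=O)c2ccc(Br)cc2)cc1O`, 1000 nM

All three were tested in a functional assay on DU-145 cells (Homo sapiens) for inhibition, read by trypan blue exclusion, with a stated time of 96 h; a higher number here means a weaker inhibitor of growth, a lower number a stronger inhibitor of growth. Compound 1 gives the highest of the three numbers, so it is the weakest inhibitor of growth here. Compound 2 sits nearest to it, with a number that is lower by a margin beyond the scatter, and compound 3 sits furthest, with a number lower by a margin also well beyond the scatter.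

The unmeasured compound 4, `CN(C)c1ccc(/C=C(/SCc2ccc(F)cc2)C(=O)c2ccc(Cl)cc2)cc1`, keeps the shared core of compound 1 and changes only the group on the saturated chain carbon bound to a sulfur:

4-fluorophenyl in place of 2,4-dichlorophenyl on a saturated chain carbon bound to a sulfur

Within the data shown here, no measured pair differs in this one place alone, so the size of this step cannot be read from the data. Compound 2 also carries a 4-fluorobenzyl arm and gives a lower number, but it differs from compound 1 in two further places, so its value cannot be attributed to the arm. The step from compound 1 to compound 4 is therefore expected to be small, in either direction, and likely within the scatter, which is what a 1.4-fold lower number from compound 1 to compound 4 (0.15 log units; within the scatter) expresses. Compound 4 is estimated at 35000 nM, with a range from 8000 nM to 100000 nM.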

Compound 4, concentration for 50% growth inhibition: 50000 nM
Compound 4: the middle estimate sits 1.4-fold (0.15 log units) below what was measured; the range from low to high includes it.
By their numbers in this assay, from the lowest: compound 3; then compound 2; then compounds 1 and 4 (each within the scatter of the next).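

In this assay, putting 4-fluorophenyl in place of 2,4-dichlorophenyl on a saturated chain carbon bound to a sulfur gives no change at the digits printed from compound 1 to compound 4 (within the scatter). Among these compounds, this is the first pair that differs in this one place alone, so the effect of the arm can now be read directly rather than guessed from compounds that differ in several places: on this shared core, the two chlorine-bearing ring gives way to the fluorine-bearing ring with no measurable shift in growth inhibition. No measurement offered here explains why the two arms read alike.

As far as these compounds go, what remains open is whether this position is insensitive in general or only to these two halogen-bearing phenyl rings, and a plain unsubstituted phenyl, a cyclohexyl ring or a phenyl carrying a carboxylic acid or an amine on this chain carbon would test that. From the compounds shown here alone, it also remains open whether the same swap would stay just as silent on a different core, since this single pair speaks only for the core of compound 1.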